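This account rests on a few compounds, and the source may have more. Where it says the series, first, only, none or still open, it means among the compounds named here.

In a functional assay on PANC cells (Homo sapiens) for antiproliferative activity, read by MTT assay, with a stated time of 3 days (on this read-out lower numbers stand for stronger inhibition and higher numbers for weaker inhibition), compound 1 `CC(C)CN1C(=O)C=C(Cl)C1(O)c1ccccc1` gives 27 nM. Among the compounds with values here, the only other measured compound, compound 2 `CC(C)CN1C(=O)C=C(Cl)C1(O)c1ccc(Cl)cc1`, gives 22 nM, so these two values lie within the scatter of each other. Compound 3 `O=C1C=C(Cl)C(O)(c2ccccc2)N1Cc1ccccc1` keeps the core of compound 1 and differs in one group: phenyl in place of isopropyl on a saturated chain carbon bound to an amide-type nitrogen in a ring. Within the data shown here, the single measured step, a 1.2-fold lower number from compound 1 to compound 2 (0.09 log units; within the scatter), comes from a different change, chloro in place of hydrogen on an aromatic carbon. Among the measured compounds shown here, no measured step tests the group that changes here, so the data favour no direction, and no shift beyond the scatter is expected in this assay, though the uncertainty is wide. The expected step is a 1.1-fold higher number from compound 1 to compound 3 (0.05 log units; within the scatter). The estimate for compound 3 is 30 nM, with an expected range from 10 nM to 90 nM.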

Compound 3, half-maximal inhibitory concentration: 674 nM
Beside the measured number, compound 3's estimate is 22-fold (1.35 log units) below it; the whole stated range lies below it.
By their numbers in this assay, from the lowest: compounds 2 and 1 (each within the scatter of the next); then compound 3.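

In this assay, phenyl in place of isopropyl on a saturated chain carbon bound to an amide-type nitrogen in a ring gives a 25-fold higher number from compound 1 to compound 3 (1.40 log units; beyond the scatter) and so counts as a large change. This is the first step shown that goes beyond the scatter, so the isobutyl of compound 1 cannot be swapped for benzyl without a clear loss of antiproliferative strength, whereas a 1.2-fold lower number from compound 1 to compound 2 (0.09 log units; within the scatter) showed no such loss for the chloro change on the aromatic carbon. Nothing measured here explains why the number rises so far.

The compounds shown leave open whether the loss follows from the aromatic ring itself or simply from a larger group, and a cyclohexyl group in place of the phenyl would separate those two readings. On these data alone, it also remains open how a longer chain or an amine at this position would behave.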